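The compounds below may be only part of what the source reports. "The series", "measured", "known", "first", "only" and "open" are said of these compounds alone.

Measured compounds:
compound 1 `Nc1sc(-c2ccc(Cl)cc2)c(-c2ccc(Cl)cc2)c1C(=O)NC1CCCCC1`, 7300 nM
compound 2 `Nc1sc(-c2ccc(Cl)cc2)c(-c2ccc(Cl)cc2)c1C(=O)NCc1ccccc1`, 31800 nM
compound 3 `CC1CN(C(=O)c2c(N)sc(-c3ccc(Cl)cc3)c2-c2ccc(Cl)cc2)CCN1`, 7210 nM

In a functional assay on PC-3 cells (Homo sapiens) for inhibition, read by sulforhodamine B assay, with a stated time of 72 h (a higher number here means a weaker inhibitor, a lower number a stronger inhibitor), compound 1 gives 7300 nM, the second highest of the three numbers; compound 3 sits closest to it, and compound 2 furthest, with a 4.4-fold higher number from compound 1 to compound 2 (0.64 log units; beyond the scatter). Compound 4 `Nc1sc(-c2ccc(Cl)cc2)c(-c2ccc(Cl)cc2)c1C(=O)NC1CCC1` has not been measured. It differs from compound 1 in one place: cyclobutyl in place of cyclohexyl on an amide-type nitrogen. Within the data shown here, none of the measured steps changes ring size on the amide-type nitrogen; the only step at that nitrogen is a 4.4-fold higher number from compound 1 to compound 2 (0.64 log units; beyond the scatter), a benzyl in place of cyclohexyl, and it is only a loose guide. Because the shift from compound 1 to compound 3 was a 1.0-fold lower number from compound 1 to compound 3 (0.01 log units; within the scatter), this position tolerates variation. Compound 4 is therefore expected near compound 1, a 1.2-fold higher number from compound 1 to compound 4 (0.09 log units; within the scatter), with an estimated 9000 nM (range 4000 nM to 25000 nM).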

Compound 4, half-maximal inhibitory concentration: 24800 nM
The estimate for compound 4 lay 2.8-fold (0.44 log units) below the measured number; the range from low to high includes it.
By their numbers in this assay, from the lowest: compounds 3 and 1 (each within the scatter of the next); then compounds 4 and 2 (each within the scatter of the next).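

In this assay, the amide-type nitrogen proves sensitive to ring size alone, with cyclobutyl in place of cyclohexyl giving a 3.4-fold higher number from compound 1 to compound 4 (0.53 log units; beyond the scatter). The cyclobutylamino compound also separates from the 3-methylpiperazin-1-yl compound, with a 3.4-fold higher number from compound 3 to compound 4 (0.54 log units; beyond the scatter), yet stays level with the benzyl compound, with a 1.3-fold lower number from compound 2 to compound 4 (0.11 log units; within the scatter), so these two replacements of cyclohexyl end up together. No measurement here offers an explanation for this shift.

Going by these compounds, whether cyclopentyl or cycloheptyl on the same nitrogen would sit with compound 1 or with compound 4 remains open. So does whether an open chain such as isopropyl would follow the rings.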